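This account rests on a few compounds, and the source may have more. Where it says the series, first, only, none or still open, it means among the compounds named here.

Measured compounds in a functional assay on U-87MG ATCC cells for antiproliferative activity against U-87 MG (Homo sapiens), read by MTT assay, with a stated time of 48 h, tested at 100 uM; a higher number here means a weaker effect of the compound at the concentration tested, a lower number a stronger effect:
Compound 1, `COc1ccc(-c2nc(C)c(C(=O)CSc3nc(-c4ccc(Cl)c(Cl)c4)c(C#N)c(=O)[nH]3)s2)cc1`, gives 31.1%.
Compound 2, `COc1ccc(-c2nc(C)c(C(=O)CSc3nc(-c4cccc(OC)c4)c(C#N)c(=O)[nH]3)s2)cc1`, gives 12.4%.
Compound 3, `COc1ccc(-c2nc(C)c(C(=O)CSc3nc(-c4ccc(OC)c(OC)c4)c(C#N)c(=O)[nH]3)s2)cc1`, gives 5.39%.

Compound 3 stands at the lowest of the three numbers in this assay. Its nearest neighbour is compound 2, separated by a number 7 percentage points lower from compound 2 to compound 3 (within the scatter), a gap within the scatter, so no order can be read between these two. Compound 1 lies furthest away, by a number 25.7 percentage points lower from compound 1 to compound 3 (beyond the scatter), a step beyond the scatter.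

Compound 4, `COc1ccc(-c2nc(C)c(C(=O)CSc3nc(-c4ccccc4)c(C#N)c(=O)[nH]3)s2)cc1`, has not yet been measured. It differs from compound 3 by phenyl in place of 3,4-dimethoxyphenyl on an aromatic carbon. Going by the values given here, the step that bears on this change most directly is the one from compound 2 to compound 3, where a methoxy in place of hydrogen shifted the number by a number 7 percentage points lower from compound 2 to compound 3 (within the scatter), within the scatter. The change from compound 1 to compound 2, a number 18.7 percentage points lower from compound 1 to compound 2 (beyond the scatter), involved the same ring but exchanged chlorine-bearing and methoxy-bearing groups, and so speaks to it only loosely. With both methoxy groups gone in compound 4, a modest rise in the number is expected, though one that may stay within the scatter of compound 3.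

For compound 4 in this assay the expected value is 15%, with a range from 4% to 32%. The expected step from compound 3 to compound 4 is therefore a number 9.6 percentage points higher from compound 3 to compound 4 (within the scatter).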

Compound 4, a percentage reported as activity, at one concentration (the size of the read-out at that concentration, not a potency): 10.9%
Beside the measured number, compound 4's estimate is 4.1 percentage points above it; the range from low to high includes it.
By their numbers in this assay, from the lowest: compounds 3, 4 and 2 (each within the scatter of the next); then compound 1.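

With the plain phenyl at this aromatic carbon, next to the ring nitrogen and ortho to a cyano group, the methoxy groups are not shown to matter in this assay: losing both gives a number 5.5 percentage points higher from compound 3 to compound 4 (within the scatter), and losing the single one gives a number 1.5 percentage points lower from compound 2 to compound 4 (within the scatter). The phenyl, 3-methoxyphenyl and 3,4-dimethoxyphenyl compounds therefore cannot be told apart here, while the unsubstituted ring still stands clear of the 3,4-dichlorophenyl compound, with a number 20.2 percentage points lower from compound 1 to compound 4 (beyond the scatter), so the separation of compound 1 does not depend on a methoxy group being present. Nothing available explains why the dichlorophenyl ring stands apart from the other three.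

From the compounds shown here alone, it remains open whether one chlorine alone, at either ring position, would already separate a compound from the phenyl group, or whether an amine or a carboxylic acid on this ring would do so. As all these readings come from one concentration, they also leave open whether compounds 2, 3 and 4 would separate at lower concentrations.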